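Removing a chloro from a dichlorinated purine benzyl compound

This account rests on a few compounds, and the source may have more. Where it says the series, first, only, none or still open, it means among the compounds named here.

Compound 1 `ClCc1ccc(Cn2cnc3c(Cl)ncnc32)cc1`: 38900 nM
Compound 2 `ClCc1ccccc1Cn1cnc2c(Cl)nc(Cl)nc21`: 3540 nM

In a functional assay on Hs-578T cells (Homo sapiens) for cytotoxicity, read by sulforhodamine B assay, with a stated time of 48 h (a lower number here means a stronger inhibitor of growth, a higher number a weaker inhibitor of growth), compound 2 gives 3540 nM, the lowest of the two numbers shown, while compound 1 gives 38900 nM, a gap beyond the scatter. Compound 3 `ClCc1ccccc1Cn1cnc2c(Cl)ncnc21` keeps the core of compound 2 and differs only by hydrogen in place of chloro on an aromatic carbon. Among the compounds with values here, no measured pair shows this change alone, so its size is uncertain; a modest loss of growth inhibition is expected, with the step of a 2.8-fold higher number from compound 2 to compound 3 (0.45 log units; beyond the scatter). Compound 3 is estimated at 10000 nM, within 3000 nM to 40000 nM.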

Compound 3, concentration for total growth inhibition: 6600 nM
Beside the measured number, compound 3's estimate is 1.5-fold (0.18 log units) above it; the range from low to high includes it.
By their numbers in this assay, from the lowest: compounds 2 and 3 (each within the scatter of the next); then compound 1.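

Read directly at this position, in this assay, hydrogen in place of chloro on the aromatic carbon between two ring nitrogen atoms gives a 1.9-fold higher number from compound 2 to compound 3 (0.27 log units; within the scatter) and so cannot be told apart from the chloro compound. In this read-out, the chloro at this position therefore shows no measurable contribution. Nothing shown explains this result. On these data alone, what stays open is whether an amine or a methoxy group at this same carbon would give a number beyond the scatter, as neither chloro nor hydrogen does here.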